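A smaller side chain and the cytotoxicity of compound 4

A few compounds are considered here, and "the series" means these few. Any claim that something is new, unique, unknown or untested is made for them only; others in the source may bear on it.

Compound 1 `CC(C)=CCN1C(=O)N(Cc2ccccc2)S(=O)(=O)n2cccc21` is the only one of the three measured compounds to give a number rather than a limit in an ADME assay on MT4 cells (Homo sapiens) for cytotoxicity, read by MTT assay, with a stated time of 5 days; a lower number here means that less compound is tolerated, a higher number that more compound is tolerated: compound 1 gives 226000 nM. Compound 2 `N#Cc1ccccc1CN1C(=O)N(Cc2cccc(Cl)c2)S(=O)(=O)n2cccc21` reaches only a limit of the assay, giving > 293000 nM. Compound 3 `O=C1N(Cc2ccc(Cl)cc2Cl)c2cccn2S(=O)(=O)N1Cc1cccc(Cl)c1` likewise reaches only a limit, giving > 251000 nM. Among the compounds with values here, the single step between measured compounds, a step that the two limits leave unreadable from compound 2 to compound 3, cannot be read, as both of its ends sit at the limits the limit of > 251000 nM in this assay, at which 1 of the 3 values shown sits, and (the limit of > 293000 nM in this assay, at which 1 of the 3 values shown sits).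

Compound 4 `N#CCN1C(=O)N(Cc2ccccc2)S(=O)(=O)n2cccc21` differs from compound 1 in one place: cyano in place of 2-methylprop-1-en-1-yl on a saturated chain carbon bound to an amide-type nitrogen in a ring. Within the data shown here, no measured step covers this change. Among the measured compounds shown here, the one step that exists, a step that the two limits leave unreadable from compound 2 to compound 3, swaps different groups at the same kind of place and has no readable size, so it offers no guidance on direction or magnitude. What the three measured compounds do show is that each is tolerated up to the high concentrations reached in this assay, whether as a number or as a limit. Compound 4 is therefore expected to behave similarly, with a step of a 1.1-fold higher number from compound 1 to compound 4 (0.03 log units; within the scatter) expected to stay within the scatter. Compound 4 is estimated to give 240000 nM, within a range from 110000 nM to 500000 nM, with a fair chance that it too reaches only a limit.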

Compound 4, half-maximal cytotoxic concentration: 180000 nM
Estimate against measurement, compound 4: 1.3-fold (0.12 log units) above, and the stated range covers the measured number.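

In this assay, the exchange of 2-methylprop-1-en-1-yl for cyano on a saturated chain carbon bound to an amide-type nitrogen in a ring gives a 1.3-fold lower number from compound 1 to compound 4 (0.10 log units; within the scatter), which lies within the usual scatter. Within the data shown here, this is the first step that can be read at all, as both of its ends are numbers, whereas the earlier step between limits cannot be read; it shows that this place accepts a branched chain with a double bond and a cyano group with a triple bond and one hydrogen-bond acceptor without a change beyond the scatter. Nothing shown here accounts for this outcome, and no measurement gives a property of either group that bears on it.

What an amine, a carboxylic acid or a longer chain would do at this place remains open, since both groups shown here are uncharged and neither carries a hydrogen-bond donor. From the compounds shown here alone, compound 2 and compound 3 end at limits and differ from compound 1 in more than one place, so it also remains open whether this result holds when the other benzyl group carries chlorine.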